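Swapping a formyl group for benzimidazole in a pyrazole series

This account rests on a few compounds, and the source may have more. Where it says the series, first, only, none or still open, it means among the compounds named here.

Measured so far:
compound 1 `O=Cc1cn(-c2ccccc2)nc1-c1ccc(Cl)cc1` — > 50000 nM
compound 2 `Fc1ccc(-c2nn(-c3ccccc3)cc2-c2nc3cc(F)ccc3[nH]2)cc1` — > 50000 nM
compound 3 `Fc1ccc(-c2nn(-c3ccccc3)cc2-c2nc3cc(Cl)c(Cl)cc3[nH]2)cc1` — 44600 nM

Of the compounds shown here, three sharing a pyrazole-based core have been tested in an ADME assay on HaCaT cells (Homo sapiens) for cytotoxicity, read by MTT assay, with a stated time of 48 h; on this read-out higher numbers stand for weaker inhibition and lower numbers for stronger inhibition. Compound 1 gives only a limit, > 50000 nM, so no number is known for it. Compound 2 likewise gives only a limit, > 50000 nM. Compound 3 gives a measured value, 44600 nM, which lies close to the same boundary. Compound 1 therefore stands where most of the set stands, namely at the limit of > 50000 nM in this assay, at which 2 of the 3 values shown sit, and nothing shown separates it from the others.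

Compound 4 `Clc1ccc(-c2nn(-c3ccccc3)cc2-c2nc3ccccc3[nH]2)cc1` has not yet been measured in this assay. It differs from compound 1 in one place: 1H-benzimidazol-2-yl in place of formyl on an aromatic carbon. Compounds 2 and 3 already carry a 1H-benzimidazol-2-yl group on their core, and both sit at or near the limit.

Given that, the expected step of a number no higher from compound 1 to compound 4 (the limit leaves the size open) is none beyond the usual scatter, with the number most likely again reported as a limit. Compound 4 is estimated at 50000 nM, within a range from 20000 nM to 120000 nM.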

Compound 4, half-maximal inhibitory concentration: > 50000 nM
Compound 4 gave a limit, no number; the forecaster's own chance of this, stated with the estimate: 60%; the middle value lies on the limit itself.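

Within the data shown here, compound 1 and compound 4 each gave only a limit of the assay, not a number, so no step between them can be read. The compounds shown leave open whether 1H-benzimidazol-2-yl in place of formyl changes the cytotoxicity at all.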